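Compound 3 after loss of the 4-fluorophenyl

A few compounds are considered here, and "the series" means these few. Any claim that something is new, unique, unknown or untested is made for them only; others in the source may bear on it.

Compound 1 `Oc1c(O)c(O)c2c(=S)cc(-c3ccccc3)oc2c1-c1ccc(F)cc1` gives > 100000 nM
Compound 2 `O=c1cc(-c2ccccc2)oc2c(-c3ccccc3)c(O)c(O)c(O)c12` gives 86300 nM

In a toxicity assay on Huh-7 cells (Homo sapiens) for cytotoxicity, read by CCK-8 assay, with a stated time of 24 h (on this read-out lower numbers stand for higher toxicity in this test and higher numbers for lower toxicity in this test), compound 1 stands at > 100000 nM, which is a limit of the assay and not a number. Going by the values given here, no measured compound therefore fixes its exact place on the scale. Compound 3 `Oc1cc2oc(-c3ccccc3)cc(=S)c2c(O)c1O` has not yet been measured. It arises from compound 1 with hydrogen in place of 4-fluorophenyl on an aromatic carbon. Among the compounds with values here, no measured pair shows what this change does, so the expectation is only a modest shift towards lower numbers in this assay. Within the data shown here, the one firm number available is that of compound 2 at 86300 nM, and the expectation stays near it. The expected size of the change is an at least 1.2-fold lower number from compound 1 to compound 3 (0.09 log units; that floor lies within the scatter). For compound 3 the estimated value is 80000 nM, with an expected range from 30000 nM to 200000 nM.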

Compound 3, half-maximal cytotoxic concentration: > 100000 nM
Compound 3 ended at the assay's limit (the forecaster's own chance of this, stated with the estimate: 45%); at least 1.2-fold (0.09 log units) between middle value and limit.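

Compound 1 and compound 3 both end at a limit of this assay and not at a number, so no step can be read between them: the limit of > 100000 nM in this assay, at which 2 of the 3 values shown sit.

The compounds shown leave open how far either lies past that limit, and so what replacing 4-fluorophenyl with hydrogen does to this read-out.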